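Piperidinyl dithiocarbamate on the unsubstituted core of compound 2

The compounds below may be only part of what the source reports. "The series", "measured", "known", "first", "only" and "open" are said of these compounds alone.

Measured compounds:
- Compound 1, `O=c1c(CSC(=S)N2CCCCC2)coc2cc(Cl)ccc12`: 280 nM
- Compound 2, `O=c1c(CSC(=S)N2CCOCC2)coc2ccccc12`: 4400 nM

Of the compounds shown here, two have been measured in a functional assay on HEp-2 cells (Homo sapiens) for antiproliferative activity, read by MTT assay, with a stated time of 72 h; on this read-out higher numbers stand for weaker inhibition and lower numbers for stronger inhibition. Compound 1, `O=c1c(CSC(=S)N2CCCCC2)coc2cc(Cl)ccc12`, gives 280 nM in this assay. Compound 2, `O=c1c(CSC(=S)N2CCOCC2)coc2ccccc12`, gives 4400 nM in this assay, the highest of the two numbers; compound 1 stands nearest, and the gap between the two values is beyond the scatter. The two compounds differ in more than one place, so the gap cannot be assigned to a single change.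

Compound 3, `O=c1c(CSC(=S)N2CCCCC2)coc2ccccc12`, has not yet been measured. It is reached from compound 2 by one change: piperidin-1-yl in place of morpholin-4-yl on a thiocarbonyl carbon. Compound 3 shares its dithiocarbamate part with compound 1 and its core with compound 2, so its value is expected to fall between those two. The step of a 4.0-fold lower number from compound 2 to compound 3 (0.60 log units; beyond the scatter) is expected to be a move toward a lower number, beyond the scatter, because compound 1 gives 280 nM while compound 2 gives 4400 nM. For compound 3 the estimate in this assay is 1100 nM, within a range from 350 nM to 3500 nM.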

Compound 3, half-maximal inhibitory concentration: 390 nM
Compound 3: the middle estimate sits 2.8-fold (0.45 log units) above what was measured; measured number inside the range.
By their numbers in this assay, from the lowest: compounds 1 and 3 (each within the scatter of the next); then compound 2.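

In this assay, the exchange of morpholin-4-yl for piperidin-1-yl on a thiocarbonyl carbon, with the rest of the molecule unchanged, gives an 11-fold lower number from compound 2 to compound 3 (1.05 log units; beyond the scatter), a large step that shows this position strongly affects the read-out. The gap between compound 1 and compound 2 could not be assigned before, but it now falls largely to this ring exchange, since hydrogen in place of chloro on an aromatic carbon gives a 1.4-fold higher number from compound 1 to compound 3 (0.14 log units; within the scatter) and that step lies within the scatter, so the chloro group makes no readable difference where piperidin-1-yl is present. Nothing available bears on why the ring exchange has so large an effect on this result.

The compounds shown leave open whether chloro would also make no readable difference where morpholin-4-yl is present, as that pairing does not appear among them. They also leave open how other amine groups on the thiocarbonyl carbon, such as piperazin-1-yl or an open-chain diethylamino group, would compare with piperidin-1-yl in this read-out.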